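A few compounds are considered here, and "the series" means these few. Any claim that something is new, unique, unknown or untested is made for them only; others in the source may bear on it.

Three amines on a shared core have been measured in a physicochemical assay for lipophilicity, using the shake flask method, measured as octanol-water partition; a lower number here means a more polar compound, a higher number a more lipophilic compound. Compound 1 (`CCN(CC)Cc1c(O)cc2c(c1O)C(=O)C[C@@H](c1ccc(OC)c(O)c1)O2`), which carries diethylamino, gives 1.68. Compound 2 (`COc1ccc([C@@H]2CC(=O)c3c(cc(O)c(CNC(C)C)c3O)O2)cc1O`), which carries isopropylamino, gives -0.26, and compound 3 (`CCC(C)NCc1c(O)cc2c(c1O)C(=O)C[C@@H](c1ccc(OC)c(O)c1)O2`), which carries (sec-butyl)amino, gives 0.04. Compound 3 therefore stands well under compound 1, at a number 1.64 log units lower from compound 1 to compound 3 (beyond the scatter), and within the scatter of compound 2, at a number 0.30 log units higher from compound 2 to compound 3 (within the scatter).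

Compound 4 (`COc1ccc([C@@H]2CC(=O)c3c(cc(O)c(CNC(C)(C)C)c3O)O2)cc1O`) has not yet been measured. It has the same atoms as compound 3, joined differently: tert-butyl in place of sec-butyl on an amine nitrogen. Among the compounds with values here, this places tert-butyl in place of sec-butyl on an amine nitrogen, and no measured compound carries tert-butyl. Within the data shown here, the two large steps, a number 1.94 log units lower from compound 1 to compound 2 (beyond the scatter) and a number 1.64 log units lower from compound 1 to compound 3 (beyond the scatter), both leave diethylamino, a change that has no counterpart here. The nearest guide is the methyl in place of hydrogen on a saturated chain carbon, which gave a number 0.30 log units higher from compound 2 to compound 3 (within the scatter). On that evidence, no step beyond the scatter is expected in this assay. The estimated step is a number 0.06 log units higher from compound 3 to compound 4 (within the scatter), with its direction left open by the scatter. The expected value for compound 4 is 0.1, with an estimated range from -0.4 to 0.6.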

Compound 4, partition coefficient: -0.76
Estimate against measurement, compound 4: 0.86 log units above; measured number outside the range, below it.
By their numbers in this assay, from the lowest: compound 4; then compounds 2 and 3 (each within the scatter of the next); then compound 1.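

In this assay, within the data shown here, tert-butyl in place of sec-butyl on an amine nitrogen gives a number 0.80 log units lower from compound 3 to compound 4 (beyond the scatter) even though the two groups hold the same atoms, so the way they are joined counts at this position, which the earlier compounds could not show. A methyl on the saturated chain carbon bound to an amine nitrogen and two saturated chain carbons gives a number 0.50 log units lower from compound 2 to compound 4 (beyond the scatter), whereas the methyl two bonds along the chain gave a number 0.30 log units higher from compound 2 to compound 3 (within the scatter), so on this chain the place of a methyl decides whether the step clears the scatter. The gap to the diethylamino compound also widens to a number 2.44 log units lower from compound 1 to compound 4 (beyond the scatter), and nothing among the data shown explains any of these differences.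

The compounds shown leave open how a straight n-butyl chain on the nitrogen, or a ring amine such as pyrrolidine or piperidine, would compare with these branched groups. They also leave open whether the high number of compound 1 goes with two chains on the nitrogen or with ethyl itself, which dimethylamino or a single ethylamino group could help separate.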